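Acetoxy to benzoyloxy: one change from compound 2

The compounds below may be only part of what the source reports. "The series", "measured", "known", "first", "only" and "open" are said of these compounds alone.

Compound 2 (`CC(=O)O[C@@H]1/C=C/[C@@](C)(CCC=C(C)C)C/C=C(/CO)C(=O)/C=C/[C@@]1(C)O`) gives 5050 nM in a functional assay on HL-60 cells (Homo sapiens) for antiproliferative activity, read by MTT assay, with a stated time of 48 h; a higher number here means a weaker inhibitor, a lower number a stronger inhibitor. Compound 1 (`CC(C)=CCC[C@](C)(/C=C/[C@@H](OC(=O)C=C(C)C)[C@](C)(O)/C=C/C(=O)/C=C/N1CCN(C)CC1)CC=O`) gives 1060 nM in this assay. Compound 2 holds the higher of the two numbers, and the gap between the two compounds lies beyond the scatter. Compound 3 (`CC(C)=CCC[C@]1(C)/C=C/[C@@H](OC(=O)c2ccccc2)[C@](C)(O)/C=C/C(=O)/C(CO)=C\C1`) differs from compound 2 by phenyl in place of methyl on a carbonyl carbon in the change acetoxy to benzoyloxy, phenyl in place of methyl on a carbonyl carbon. Going by the values given here, no measured pair isolates this change, so the expectation rests on judgement alone. The estimated step of a 1.8-fold lower number from compound 2 to compound 3 (0.26 log units; within the scatter) is a modest fall in this assay and may stay close to the scatter. The expected value for compound 3 is 2800 nM (expected range 900 nM to 7500 nM).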

Compound 3, half-maximal inhibitory concentration: 22600 nM
Compound 3: middle estimate off by 8.1-fold (0.91 log units), on the low side; measured number outside the range, above it.
By their numbers in this assay, from the lowest: compound 1; then compound 2; then compound 3.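

In this assay, phenyl in place of methyl on a carbonyl carbon gives a 4.5-fold higher number from compound 2 to compound 3 (0.65 log units; beyond the scatter), a step beyond the scatter, so this ester position is sensitive to the change and the benzoyloxy ester carries the weaker activity. Going by these compounds alone, this is the only single-place comparison, as compound 1 differs from both compounds in more than one place. Nothing measured here explains the step.

Still open, from the compounds shown here alone, is how a butyryloxy ester, with its longer chain, or a cyclohexanecarbonyloxy ester, with a saturated ring, would read at this position. Going by these compounds, whether the step carries over to the core of compound 1 is also open.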